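Methoxy to hydroxy on the aryl of compound 3

This account rests on a few compounds, and the source may have more. Where it says the series, first, only, none or still open, it means among the compounds named here.

Measured compounds:
- compound 1 `COc1cc(C)cc(-c2c(-c3ccnc(-c4ccc(C(C)=O)cc4)c3)cnn2CC#N)c1`: in a functional assay on SR cells (Homo sapiens) for inhibition, read by sulforhodamine B assay, with a stated time of 48 h (on this read-out higher numbers stand for weaker inhibition of growth and lower numbers for stronger inhibition of growth), compound 1 gives > 100000 nM, a limit of the assay.
- compound 2 `Cc1cc(O)cc(-c2nn(CC#N)cc2-c2ccnc(-c3ccc(Oc4ccccc4)cc3)c2)c1`: in this assay compound 2 gives 37200 nM.
- compound 3 `COc1cc(C)cc(-c2nn(CC#N)cc2-c2ccnc(-c3ccc(N(C)C)cc3)c2)c1`: in this assay compound 3 gives > 10000 nM, a limit of the assay.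

Compound 3 stands at the limit of > 10000 nM in this assay, at which 1 of the 3 values shown sits, so only a ceiling on its potency is known. Compound 1 stands at the limit of > 100000 nM in this assay, at which 1 of the 3 values shown sits. Within the data shown here, compound 2 is the only member with a numerical value, and that value is weak. Among the measured compounds shown here, no step between two measured compounds that differ in one place is available, so the size of the change in hand has no measured precedent.

Compound 4 `Cc1cc(O)cc(-c2nn(CC#N)cc2-c2ccnc(-c3ccc(N(C)C)cc3)c2)c1` differs from compound 3 by hydrogen in place of methyl on an oxygen on an aromatic ring. Compound 2 carries the same hydroxy group and gives 37200 nM, a weak but measurable value. For compound 4 the step that the limit leaves unreadable from compound 3 to compound 4 is therefore expected to be small, likely within the scatter, with a fair chance that the assay again reports only a limit. Compound 4 is estimated at 30000 nM, with a range from 8000 nM to 100000 nM.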

Compound 4, concentration for total growth inhibition: > 100000 nM
Compound 4 gave a limit, no number; the forecaster's own chance of this, stated with the estimate: 50%; at least 3.3-fold (0.52 log units) between middle value and limit.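

The methoxy to hydroxy change cannot be sized in this assay: compound 3 and compound 4 are both known only as limits, so the step between them cannot be read. Compound 4, which carries the hydroxy group, gives > 100000 nM, a limit of the assay, so the hydroxy group alone does not secure a measurable value. Among these compounds, with the 3-hydroxy-5-methylphenyl held, dimethylamino in place of phenoxy gives an at least 2.6-fold higher number from compound 2 to compound 4 (0.42 log units; beyond the scatter), the first readable step, and it shows that the measurable value of compound 2 does not survive this exchange.

Still open, on these data alone, is how methoxy to hydroxy reads with phenoxy kept in place, where a number might be obtained on both sides. Also open, as far as these compounds go, is whether a carboxylic acid or a benzyloxy group in place of phenoxy would give a measurable value.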